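The source may report more compounds than this note shows. Statements on the series, on what has been measured and on what is new or still open speak of the compounds shown alone.

Measured so far in a functional assay on MCF7 cells (Homo sapiens) for cytotoxicity, read by MTT assay, with a stated time of 72 h; a higher number here means a weaker inhibitor of growth, a lower number a stronger inhibitor of growth:
- compound 1 `N#C[Se]c1ccc(NC(=O)Oc2ccc(F)cc2)cc1` gives 8300 nM
- compound 2 `N#C[Se]c1ccc(NC(=O)Oc2ccccc2)cc1` gives 4000 nM
- compound 3 `N#C[Se]c1ccc(NC(=O)Oc2ccc(Cl)cc2)cc1` gives 6000 nM

Compound 3 stands second highest of the three numbers in this assay. Its nearest neighbour is compound 1: the change a 1.4-fold lower number from compound 1 to compound 3 (0.14 log units; within the scatter) stays within the scatter. Its furthest is compound 2: the change a 1.5-fold higher number from compound 2 to compound 3 (0.18 log units; within the scatter) also stays within the scatter. For the measured compounds named here, the only step that goes beyond the scatter is a 2.1-fold lower number from compound 1 to compound 2 (0.32 log units; beyond the scatter), which does not involve compound 3.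

Compound 4 `Cc1ccc(OC(=O)Nc2ccc([Se]C#N)cc2)cc1` differs from compound 3 in one place: methyl in place of chloro on an aromatic carbon. Going by the values given here, no measured pair shows methyl entering at this place, so the steps that bear on it are the two that vary the same position on the same ring, from compound 1 to compound 3 and from compound 2 to compound 3, both within the scatter. Exchange of the group at this position has so far moved the number by little, so for compound 4 the expected step in this assay is small in either direction and is estimated at a 1.2-fold lower number from compound 3 to compound 4 (0.08 log units; within the scatter), not beyond the scatter.

Compound 4 is therefore estimated at 5000 nM, with a range of 2500 nM to 10000 nM.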

Compound 4, concentration for 50% growth inhibition: 9900 nM
Compound 4: middle estimate off by 2.0-fold (0.30 log units), on the low side, and the stated range covers the measured number.
By their numbers in this assay, from the lowest: compounds 2, 3, 1 and 4 (each within the scatter of the next, the first and the last beyond it).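

Methyl at this place joins fluoro in standing apart from hydrogen in this assay, with a 2.5-fold higher number from compound 2 to compound 4 (0.39 log units; beyond the scatter) as the step beyond the scatter, whereas chloro's step from hydrogen stays within it. The other two steps, a 1.7-fold higher number from compound 3 to compound 4 (0.22 log units; within the scatter) and a 1.2-fold higher number from compound 1 to compound 4 (0.08 log units; within the scatter), stay within the scatter, so methyl, chloro and fluoro are not separated from one another here. Nothing given here explains these steps.

The compounds shown leave open whether an amine, a methoxy group or a carboxylic acid at this place would stand apart from methyl, chloro and fluoro. They also leave open whether a longer chain, such as ethyl or propyl, would stay with methyl or move further from hydrogen.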